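A few compounds are considered here, and "the series" means these few. Any claim that something is new, unique, unknown or untested is made for them only; others in the source may bear on it.

For the measured compounds named here, compound 3 `CCCOc1nc(N)c2nc(O)n(Cc3ccccc3)c2n1` stands second highest of the three numbers so far in a functional assay on the whole organism for activation, with Mus musculus as the target; on this read-out lower numbers stand for an effect already at smaller amounts and higher numbers for an effect only at larger amounts of compound: compound 3 gives 0.3 mg/kg. Its nearest neighbour is compound 1 `CCSc1nc(N)c2nc(O)n(Cc3ccccc3)c2n1`, which in this assay gives 0.1 mg/kg, with a 3.0-fold higher number from compound 1 to compound 3 (0.48 log units; beyond the scatter) for the exchange of propoxy in place of ethylsulfanyl on an aromatic carbon. Furthest away is compound 2 `Nc1ncnc2c1nc(O)n2Cc1ccccc1`, which gives 30 mg/kg, and the step of a 100-fold lower number from compound 2 to compound 3 (2.00 log units; beyond the scatter) shows how much the propoxy group at that aromatic carbon lowers the dose compared with hydrogen.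

Compound 4 `COc1nc(N)c2nc(O)n(Cc3ccccc3)c2n1` is the next case. The change from compound 3 is hydrogen in place of ethyl on a saturated chain carbon bound to an oxygen on an aromatic ring. Going by the values given here, no measured step shortens this chain directly. Among the compounds with values here, the steps that bear on it are a 100-fold lower number from compound 2 to compound 3 (2.00 log units; beyond the scatter), which shows that having a group at that carbon rather than hydrogen matters a great deal, and a 3.0-fold higher number from compound 1 to compound 3 (0.48 log units; beyond the scatter), which shows that two different groups of similar length differ only modestly. Since methoxy keeps the oxygen but loses two chain carbons, a modest rise in dose is expected, smaller than the step to hydrogen. For compound 4 the estimated step in this assay is a 3.3-fold higher number from compound 3 to compound 4 (0.52 log units; beyond the scatter). Compound 4 is therefore expected to give about 1 mg/kg, with a range from 0.3 mg/kg to 3 mg/kg.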

Compound 4, minimum effective dose: > 1 mg/kg
Compound 4: no number, only a limit; the forecaster's own chance of this, stated with the estimate: 5%; the middle value lies on the limit itself.
By their numbers in this assay, from the lowest: compound 1; then compound 3; then compound 2.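

In this assay compound 4 gives no number, only a limit: the limit of > 1 mg/kg in this assay, at which 1 of the 4 values shown sits.

Even so, the limit shows for the first time that the length of the chain on this oxygen matters: taking propoxy to methoxy, with hydrogen in place of ethyl on the saturated chain carbon, gives an at least 3.3-fold higher number from compound 3 to compound 4 (0.52 log units; beyond the scatter), so keeping the oxygen alone does not hold the dose of compound 3. Measured against ethylsulfanyl, the methoxy exchange gives an at least 10-fold higher number from compound 1 to compound 4 (1.00 log units; beyond the scatter), a wider gap than the modest one seen earlier for propoxy, while the step between compound 2 and compound 4 cannot be read from the limit.

Going by these compounds, how large the true dose of compound 4 is remains open, and with it how much of the large gain over hydrogen methoxy retains. Also open, on these data alone, is whether a longer chain such as butoxy, or an amine at the same aromatic carbon, would match or pass the propoxy of compound 3 or the ethylsulfanyl of compound 1.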